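Chloro to bromo on the styryl ring of a chromone series

This account rests on a few compounds, and the source may have more. Where it says the series, first, only, none or still open, it means among the compounds named here.

Working notes on a small set of styryl chromones tested in a functional assay on HeLa cells (Homo sapiens) for antiproliferative activity, read by MTT assay, with a stated time of 12 h; on this read-out lower numbers stand for stronger inhibition and higher numbers for weaker inhibition. Compound 1 `COc1cc(OC)c2c(=O)cc(/C=C/c3ccc(Cl)cc3)oc2c1` carries a 4-chlorophenyl group on the styryl arm; in this assay compound 1 gives 14200 nM. Compound 2 `COc1cc(/C=C/c2cc(=O)c3c(OC)cc(OC)cc3o2)cc(OC)c1` carries a dimethoxyphenyl group in the same position; in this assay compound 2 gives 16700 nM. The two numbers lie within the scatter of each other, so neither compound can be set apart from the other on these data, and compound 1 stands level with compound 2 rather than ahead of it.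

Compound 3 `COc1cc(OC)c2c(=O)cc(/C=C/c3ccc(Br)cc3)oc2c1` is the next member. It differs from compound 1 by bromo in place of chloro on an aromatic carbon. Among the measured compounds shown here, no measured pair in the set changes a single substituent on this ring, so there is no direct precedent for the size of the step. A swap of one halogen for another at the same aromatic carbon is expected to leave the number roughly where it is, within the scatter or close to its edge. Compound 3 is therefore estimated at 12000 nM, within 5000 nM to 30000 nM, which means an expected step of a 1.2-fold lower number from compound 1 to compound 3 (0.07 log units; within the scatter).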

Compound 3, half-maximal inhibitory concentration: > 40000 nM
Compound 3 ended at the assay's limit; the forecaster's own chance of this, stated with the estimate: 5%; middle value at least 3.3-fold (0.52 log units) away from the limit.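

Bromo in place of chloro on an aromatic carbon, para to a large group, is not a neutral swap in this series: in this assay the change gives an at least 2.8-fold higher number from compound 1 to compound 3 (0.44 log units; beyond the scatter). Among the compounds shown here, the value of compound 3 is a limit of the assay and not a number, so this step gives only a minimum size and the true distance remains unknown: the limit of > 40000 nM in this assay, at which 1 of the 3 values shown sits. This is the first single-substituent pair in the set, and it shows that the number can respond to one halogen exchange at this carbon, which the earlier compounds could not show.

The compounds shown leave open whether this step is specific to bromo or would also appear with other groups at the same carbon, and they do not separate one possible explanation from another. A fluoro group, an amine or a carboxylic acid on this carbon of the styryl ring, each with the core of compound 1 kept unchanged, would show whether the 4-chlorophenyl arm is tolerated as an exception or belongs to a broader range of acceptable groups.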